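This account rests on a few compounds, and the source may have more. Where it says the series, first, only, none or still open, it means among the compounds named here.

Measured so far in a functional assay on WI-38 VA13 cells (Homo sapiens) for cytotoxicity; on this read-out higher numbers stand for an effect only at larger amounts of compound and lower numbers for an effect already at smaller amounts:
Compound 1, `COc1ccc(OC)c(C(=O)c2sc3nc(-c4cccs4)ccc3c2N)c1`, gives 0.079 ug/mL.
Compound 2, `CCC(=O)c1sc2nc(-c3cccs3)ccc2c1N`, gives 0.89 ug/mL.
Compound 3, `Nc1c(C(=O)c2cccc([N+](=O)[O-])c2)sc2nc(-c3cccs3)ccc12`, gives 0.15 ug/mL.

Among these three, compound 2 stands with the highest number. Its nearest neighbour is compound 3, whose number is lower by a gap beyond the scatter, and compound 1 lies further away still, also beyond the scatter. Both compounds with lower numbers carry an aromatic ring on the carbonyl carbon, whereas compound 2 carries an ethyl chain there.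

Compound 4, `Nc1c(C(=O)c2ccc(Br)cc2)sc2nc(-c3cccs3)ccc12`, has not yet been measured. It differs from compound 2 in one place: 4-bromophenyl in place of ethyl on a carbonyl carbon. With this change compound 4 resembles compound 1 and compound 3 in having an aromatic ring on the carbonyl carbon. Among the measured compounds shown here, no measured pair shows this exact change, so the size of the step cannot be read off directly. Because compound 1 gives 0.079 ug/mL and compound 3 gives 0.15 ug/mL, a downward step beyond the scatter is expected in this assay, namely a 5.9-fold lower number from compound 2 to compound 4 (0.77 log units; beyond the scatter). Compound 4 is therefore estimated at 0.15 ug/mL, with a range from 0.05 ug/mL to 0.5 ug/mL.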

Compound 4, half-maximal effective concentration: 2.8 ug/mL
Estimate against measurement, compound 4: 19-fold (1.27 log units) below; measured number above the stated range.
By their numbers in this assay, from the lowest: compounds 1 and 3 (each within the scatter of the next); then compound 2; then compound 4.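

In this assay the change to 4-bromophenyl in place of ethyl on the carbonyl carbon brings a 3.1-fold higher number from compound 2 to compound 4 (0.50 log units; beyond the scatter) and so the effect now needs a larger amount of compound. An aromatic ring at this position therefore does not by itself go with a lower number: compound 4 carries one and gives (2.8 ug/mL), whereas compound 3 gives (0.15 ug/mL) and compound 1 gives (0.079 ug/mL), which makes compound 4 the exception among the three aromatic members. Nothing measured here accounts for this reversal.

As far as these compounds go, how a plain phenyl, a longer chain such as butyl, or a phenyl ring carrying an amine would compare with ethyl and 4-bromophenyl stays open. The share of the bromine in this step therefore cannot yet be told apart from that of the ring.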